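This account rests on a few compounds, and the source may have more. Where it says the series, first, only, none or still open, it means among the compounds named here.

In a functional assay on DU-145 cells (Homo sapiens) for antiproliferative activity, read by propidium iodide staining, with a stated time of 96 h (on this read-out higher numbers stand for weaker inhibition and lower numbers for stronger inhibition), compound 3 (`CC(O)(CSc1cccc(S(F)(F)(F)(F)F)c1)C(=O)Nc1ccc(C#N)cc1C(F)(F)F`) gives 37400 nM. This is level, within the scatter, with compound 1 (`CC(O)(CSc1cccc(S(F)(F)(F)(F)F)c1)C(=O)Nc1ccc(C#N)c(C(F)(F)F)c1`) at 32700 nM, while compound 2 (`CC(O)(CSc1ccc(S(F)(F)(F)(F)F)cc1)C(=O)Nc1ccc(C#N)cc1C(F)(F)F`) gives 17700 nM, a lower number beyond the scatter. Compound 4 (`CC(O)(CSc1cccc(S(F)(F)(F)(F)F)c1)C(=O)Nc1ccc([N+](=O)[O-])cc1C(F)(F)F`) differs from compound 3 by having nitro in place of cyano on an aromatic carbon. Among the measured compounds shown here, no measured pair shows this swap, so the data offer no direct guide to its size. With compound 3 at 37400 nM as the anchor, no change beyond the scatter is expected in this assay, and no firm direction can be expected either. The estimated step is a 1.2-fold lower number from compound 3 to compound 4 (0.10 log units; within the scatter). Compound 4 is estimated at 30000 nM, with an expected range of 13000 nM to 65000 nM.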

Compound 4, half-maximal inhibitory concentration: 18900 nM
Beside the measured number, compound 4's estimate is 1.6-fold (0.20 log units) above it; the measured number falls inside the stated range.
By their numbers in this assay, from the lowest: compounds 2, 4, 1 and 3 (each within the scatter of the next, the first and the last beyond it).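

In this assay, among the compounds shown here, the first direct reading of nitro in place of cyano on an aromatic carbon, meta to a trifluoromethyl group and para to a large group, is a 2.0-fold lower number from compound 3 to compound 4 (0.30 log units; within the scatter), so the two groups cannot be told apart here. Nothing measured on hand offers an explanation for this result. On these data alone, whether an amine or a carboxylic acid on this carbon would shift the number beyond the scatter remains open. So does whether the same swap would stay as small with other groups elsewhere on the shared core.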